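Propyl for Phenyl on the Chain Beside the Sulfonyl

The source may report more compounds than this note shows. Statements on the series, on what has been measured and on what is new or still open speak of the compounds shown alone.

Of the compounds shown here, three on one shared core have been measured. Compound 1 `CCCCCCCCCCS(=O)(=O)/C=C/c1ccc(O)c(O)c1` gives 6800 nM in a functional assay, read by fluorescence and spectrophotometry, with a stated time of 1 h; on this read-out higher numbers stand for an effect only at larger amounts of compound and lower numbers for an effect already at smaller amounts. Compound 2 `CCCCCCCCCCCCS(=O)(=O)/C=C/c1ccc(O)c(O)c1` gives 8500 nM in this assay, and compound 3 `O=S(=O)(/C=C/c1ccc(O)c(O)c1)CCCc1ccccc1` gives 11500 nM. Of these three numbers compound 3 carries the highest, yet its gaps to the other two lie within the scatter, so no order among them can be read. The two measured steps were both small: a 1.3-fold higher number from compound 1 to compound 2 (0.10 log units; within the scatter) and a 1.7-fold higher number from compound 1 to compound 3 (0.23 log units; within the scatter).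

Compound 4 `CCCCCCS(=O)(=O)/C=C/c1ccc(O)c(O)c1` differs from compound 3 in one place: propyl in place of phenyl on a saturated chain carbon, three bonds along the chain from a sulfonyl sulfur. The step from compound 1 to compound 3, which put a phenyl where a heptyl stood at this same place, is the one that bears on the change, and it stayed within the scatter. Compound 4 is therefore expected to show a 1.3-fold lower number from compound 3 to compound 4 (0.11 log units; within the scatter) in this assay, a step not beyond the scatter. The estimate for compound 4 is 9000 nM, with a range from 4500 nM to 18000 nM.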

Compound 4, half-maximal effective concentration: 7300 nM
Estimate against measurement, compound 4: 1.2-fold (0.09 log units) above; the range from low to high includes it.
By their numbers in this assay, from the lowest: compounds 1, 4, 2 and 3 (each within the scatter of the next).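

Propyl in place of phenyl on a saturated chain carbon, three bonds along the chain from a sulfonyl sulfur, gives a 1.6-fold lower number from compound 3 to compound 4 (0.20 log units; within the scatter) in this assay on the shared core, so the ring of compound 3 and the open chain of compound 4 cannot be told apart on this read-out. The chain of compound 4 is also shorter than those of the other two straight-chain compounds, yet the steps remain small, with a 1.2-fold lower number from compound 2 to compound 4 (0.07 log units; within the scatter) and a 1.1-fold higher number from compound 1 to compound 4 (0.03 log units; within the scatter), and no dependence on chain length can be read among these compounds. Nothing available bears on why these steps are so small.

Going by these compounds, what stays open is whether any group at this place can move the number beyond the scatter in this assay at all. An amine or a carboxylic acid on the chain, or a chain longer than that of compound 2, would be the next groups to answer this.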